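Azido cytidine analogues: single stereocentre inversion, antiproliferative readout

The source may hold more compounds than are shown below. What is called first, only, known or untested is meant among the compounds shown, and "the series" means these compounds.

Measured so far:
compound 1 `[N-]=[N+]=N[C@]1(CO)O[C@@H](n2ccc(N)nc2=O)[C@H](O)[C@H]1O` – "not determined" (no result reported)
compound 2 `[N-]=[N+]=N[C@@]1(CO)C[C@@H](O)[C@H](n2ccc(N)nc2=O)O1` – "not determined" (no result reported)
compound 3 `[N-]=[N+]=N[C@]1(CO)O[C@@H](n2ccc(N)nc2=O)[C@@H](O)[C@@H]1O` – < 100000 nM

In a functional assay on 2209-23 cells (Homo sapiens) for antiproliferative activity, read by scintillation proximity assay and thymidine incorporation (a lower number here means a stronger inhibitor, a higher number a weaker inhibitor), compound 1 gives "not determined" (no result reported) and compound 2 gives "not determined" (no result reported), so neither offers a number. In this assay compound 3 gives < 100000 nM; this is a limit of the assay, not a number. Compound 3 therefore stands as the only entry with any result at all, and that result is a limit (the limit of < 100000 nM in this assay, at which 1 of the 3 values shown sits). Compound 1 and compound 3 are drawn differently at one place, one with a defined configuration and the other without (the fact that one of compounds 1 and 3 is drawn with a defined configuration and the other without, at the place where they differ), but with no number for either nothing can be read from that pair.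

Compound 4 `[N-]=[N+]=N[C@]1(CO)O[C@@H](n2ccc(N)nc2=O)[C@H](O)[C@@H]1O` is the next entry. Relative to compound 3 the change is the two compounds have the same atoms and bonds; at least one stereo element is drawn with a configuration in one of them and without one in the other: 1 of 5 stereo elements differ; a stereocentre at a saturated ring carbon is drawn S in compound 3 and R in compound 4. Among the measured compounds shown here, no step between measured compounds exists, so no size can be derived from the series. With compound 3 showing only < 100000 nM, the expectation for compound 4 is a step that the limit leaves unreadable from compound 3 to compound 4 that is not beyond the scatter, on the weak side. Compound 4 is estimated at 50000 nM, within 5000 nM to 300000 nM.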

Compound 4, half-maximal inhibitory concentration: < 100000 nM
Compound 4: a limit, no number (the forecaster's own chance of this, stated with the estimate: 60%); the middle value lies beyond the limit too.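

Compound 3 and compound 4, drawn S and R at one saturated ring carbon, both return a limit and not a number, so the step between them cannot be read. From the compounds shown here alone, whether that stereocentre affects antiproliferative potency at all, and in which direction, remains open.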